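Swapping the Quinoline for an Indole on the Shared Core

A few compounds are considered here, and "the series" means these few. Any claim that something is new, unique, unknown or untested is made for them only; others in the source may bear on it.

Compound 1 `Cc1ccc(S(=O)(=O)c2cc3cnc(Nc4cccc5cccnc45)nc3n(C)c2=O)cc1`: 10000 nM
Compound 2 `Cn1c(=O)c(C(=O)Nc2ccc(F)cc2F)cc2cnc(Nc3ccc4[nH]ccc4c3)nc21`: 5000 nM
Compound 3 `Cn1c(=O)c(S(=O)(=O)c2ccc(F)cc2N)cc2cnc(Nc3ccc4[nH]ccc4c3)nc21`: 2000 nM

In a functional assay on K562 cells (Homo sapiens) for inhibition, read by trypan blue exclusion, with a stated time of 72 h (on this read-out lower numbers stand for stronger inhibition and higher numbers for weaker inhibition), compound 1 gives 10000 nM, the highest of the three numbers. Compound 2 gives 5000 nM, a gap from compound 1 that lies within the scatter, so the two cannot be told apart. Compound 3 gives 2000 nM, and its distance from compound 1 does lie beyond the scatter.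

Among the compounds with values here, the only measured step, a 2.5-fold lower number from compound 2 to compound 3 (0.40 log units; beyond the scatter), concerns the group on the aromatic carbon of the core and leaves the amine substituent untouched. It therefore says nothing direct about the move from compound 1 to compound 4 `Cc1ccc(S(=O)(=O)c2cc3cnc(Nc4cccc5[nH]ccc45)nc3n(C)c2=O)cc1`, which is 1H-indol-4-yl in place of quinolin-8-yl on a nitrogen on an aromatic ring. Within the data shown here, no pair of measured compounds differs in exactly this way, so the expectation rests on compound 1 alone.

Among the measured compounds shown here, with the starting point at 10000 nM for compound 1 and no guiding step, the expected change a 1.7-fold lower number from compound 1 to compound 4 (0.22 log units; within the scatter) is small, leaning toward a lower number but not clearly beyond the scatter. Compound 4 is therefore estimated at 6000 nM, within a range from 1500 nM to 20000 nM.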

Compound 4, half-maximal inhibitory concentration: 5000 nM
Beside the measured number, compound 4's estimate is 1.2-fold (0.08 log units) above it; low and high end bracket the measured number.
By their numbers in this assay, from the lowest: compound 3; then compounds 2, 4 and 1 (each within the scatter of the next).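

In this assay, within the data shown here, this is the first direct look at the group on the amine nitrogen of the shared core, and replacing quinolin-8-yl with 1H-indol-4-yl gives a 2.0-fold lower number from compound 1 to compound 4 (0.30 log units; within the scatter), so compound 1 and compound 4 cannot be told apart. The swap is a real change in structure: a five-membered aromatic ring with a hydrogen-bond donor enters, and a six-membered aromatic ring with a hydrogen-bond acceptor leaves, yet the read-out shows no difference that can be separated from ordinary assay variation. No supporting data bear on how the read-out responds to this swap, so the result stands as an observation without an explanation.

From the compounds shown here alone, what remains open is whether any group on this nitrogen can shift the number beyond the scatter, for instance a plain phenyl ring or a phenyl ring carrying a longer chain that ends in an amine. Going by these compounds, it is also open whether the same swap from quinolin-8-yl to 1H-indol-4-yl would behave the same way with a different group on the aromatic carbon of the core, such as (2-amino-4-fluorophenyl)sulfonyl.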